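From hydrogen to 3-(piperidin-1-yl)propyl at the assay limit

The source may report more compounds than this note shows. Statements on the series, on what has been measured and on what is new or still open speak of the compounds shown alone.

Measured in a functional assay on K562 cells (Homo sapiens) for antiproliferative activity, read by MTT assay, with a stated time of 48 h; a higher number here means a weaker inhibitor, a lower number a stronger inhibitor:
- Compound 1 `Cn1cc(C2=C(c3nn(CCCn4cncn4)c4ncccc34)C(=O)NC2=O)c2ccccc21`: limit > 100000 nM
- Compound 2 `Cn1cc(C2=C(c3n[nH]c4ncccc34)C(=O)NC2=O)c2ccccc21`: limit > 100000 nM

Compound 2 gives only a limit, > 100000 nM, and no number. Compound 3 `Cn1cc(C2=C(c3nn(CCCN4CCCCC4)c4ncccc34)C(=O)NC2=O)c2ccccc21` carries 3-(piperidin-1-yl)propyl in place of hydrogen on an aromatic nitrogen. Within the data shown here, the one measured step on that nitrogen is a step that the two limits leave unreadable from compound 1 to compound 2, so compound 1 offers no readable size, and the limit of > 100000 nM in this assay, at which 2 of the 2 values shown sit, is all that the data show. Only a modest move towards a lower number is therefore expected, and a further limit remains quite possible. The expected step is an at least 2.0-fold lower number from compound 2 to compound 3 (0.30 log units; that floor lies within the scatter). For compound 3 the estimated value is 50000 nM, with an expected range of 10000 nM to 200000 nM.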

Compound 3, half-maximal inhibitory concentration: 5960 nM
Estimate against measurement, compound 3: 8.4-fold (0.92 log units) above, outside the stated range (below it).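

Placing 3-(piperidin-1-yl)propyl on the aromatic nitrogen gives an at least 16-fold lower number from compound 2 to compound 3 (1.22 log units; beyond the scatter). The propyl chain alone does not account for this, since piperidin-1-yl in place of 1H-1,2,4-triazol-1-yl on the chain gives an at least 16-fold lower number from compound 1 to compound 3 (1.22 log units; beyond the scatter). In this assay compound 3 is thus the only compound here with a number rather than a limit: the limit of > 100000 nM in this assay, at which 2 of the 3 values shown sit.

The compounds shown do not tell whether the piperidine nitrogen or the ring as a whole matters, which a morpholine, a dimethylamino group or a cyclohexyl ring on the same chain would address. Going by these compounds, how a shorter or longer chain would fare also remains open.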